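Lengthening the Alkyl Chain From Compound 2

The source may hold more compounds than are shown below. What is called first, only, known or untested is meant among the compounds shown, and "the series" means these compounds.

Compound 1 (`O=C(Nc1ccccc1)C1CCN(C/C=C/c2ccccc2)CC1`) gives 69700 nM in a functional assay on A549 cells (Homo sapiens) for inhibition, read by MTT assay, with a stated time of 72 h (on this read-out higher numbers stand for weaker inhibition and lower numbers for stronger inhibition), and compound 2 (`Cc1ccc(NC(=O)C2CCN(C/C=C/c3ccccc3)CC2)cc1`) gives 29600 nM on the same read-out, while compound 3 (`CCCc1ccc(NC(=O)C2CCN(C/C=C/c3ccccc3)CC2)cc1`) gives 9470 nM there. Compound 2 thus holds the middle of the three numbers. Compound 4 (`CCCCCc1ccc(NC(=O)C2CCN(C/C=C/c3ccccc3)CC2)cc1`) differs from it by butyl in place of hydrogen on a saturated chain carbon bound to an aromatic carbon. Going by the values given here, two measured steps bear on this change: the smaller ethyl addition gave a 3.1-fold lower number from compound 2 to compound 3 (0.49 log units; beyond the scatter) and the methyl addition gave a 2.4-fold lower number from compound 1 to compound 2 (0.37 log units; beyond the scatter) in the same direction. Both are modest, and a further fall with the longer chain is expected. An estimated step of a 6.6-fold lower number from compound 2 to compound 4 (0.82 log units; beyond the scatter) is therefore expected in this assay for this change. For compound 4 the estimated value is 4500 nM with an expected range from 1800 nM to 11000 nM on this read-out.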

Compound 4, half-maximal inhibitory concentration: 3880 nM
The estimate for compound 4 lay 1.2-fold (0.06 log units) above the measured number; low and high end bracket the measured number.
By their numbers in this assay, from the lowest: compound 4; then compound 3; then compound 2; then compound 1.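

In this assay the numbers keep falling as the chain grows beyond the propyl of compound 3 to the pentyl of compound 4 (a 2.4-fold lower number from compound 3 to compound 4 (0.39 log units; beyond the scatter)), and the added butyl gives a step (a 7.6-fold lower number from compound 2 to compound 4 (0.88 log units; beyond the scatter)) larger than either earlier addition. Against the unsubstituted compound, pentyl gives the only large step in the set (an 18-fold lower number from compound 1 to compound 4 (1.25 log units; beyond the scatter)), and none of the four compounds goes against the trend. No evidence here accounts for this trend. On these data alone, whether a hexyl or longer chain extends the fall remains open, as does the effect of an amine or carboxylic acid at the chain end.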